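A few compounds are considered here, and "the series" means these few. Any claim that something is new, unique, unknown or untested is made for them only; others in the source may bear on it.

Of the compounds shown here, three have been measured in a functional assay on 786-0 cells (Homo sapiens) for inhibition, read by sulforhodamine B assay, with a stated time of 48 h; on this read-out higher numbers stand for weaker inhibition of growth and lower numbers for stronger inhibition of growth. Compound 1 `N=C(N)c1ccc(-c2ccc(-c3cc(Cl)cc(Cl)c3)s2)s1` gives 1980 nM, compound 2 `COc1ccc(-c2ccc(-c3ccc(C(=N)N)o3)o2)cc1` gives 2220 nM, and compound 3 `COc1cc(OC)cc(-c2ccc(-c3ccc(C(=N)N)o3)o2)c1` gives 4150 nM. Compound 2 holds the second highest of these three numbers, but its gaps to compound 1 and to compound 3 both lie within the usual scatter, so no order can be read among them. Compound 4 `N=C(N)c1ccc(-c2ccc(-c3ccccc3)o2)o1` is compound 2 with a single change: hydrogen in place of methoxy on an aromatic carbon. Among the compounds with values here, no step of this kind has been measured here, so the expectation rests only on the narrow spread of the three numbers. The estimated step is a 1.1-fold higher number from compound 2 to compound 4 (0.05 log units; within the scatter), most likely none beyond the scatter. Compound 4 is therefore expected to give about 2500 nM, within 1000 nM to 6500 nM.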

Compound 4, concentration for 50% growth inhibition: 1740 nM
Beside the measured number, compound 4's estimate is 1.4-fold (0.16 log units) above it; low and high end bracket the measured number.
By their numbers in this assay, from the lowest: compounds 4, 1, 2 and 3 (each within the scatter of the next, the first and the last beyond it).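

In this assay, replacing methoxy with hydrogen on this aromatic carbon, para to a large group, gives a 1.3-fold lower number from compound 2 to compound 4 (0.11 log units; within the scatter) and so stays within the scatter. This single change therefore shows that, on this core, methoxy at this place can be lost without a clear change in growth inhibition. No separate data bear on why the number holds. On these data alone, whether an amine, a carboxylic acid or a longer chain such as ethoxy at this place would move the number remains open.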